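Thioether side chain variation on the shared core

This account rests on a few compounds, and the source may have more. Where it says the series, first, only, none or still open, it means among the compounds named here.

Measured compounds:
compound 1, `O=c1c2ccccc2[se]n1-c1nc(SCc2ccccc2)n[nH]1`: > 50000 nM in a functional assay on HeLa cells (Homo sapiens) for antiproliferative activity, read by CCK-8 assay, with a stated time of 48 h; on this read-out higher numbers stand for weaker inhibition and lower numbers for stronger inhibition
compound 2, `CCCCCCSc1n[nH]c(-n2[se]c3ccccc3c2=O)n1`: 35900 nM
compound 3, `O=c1c2ccccc2[se]n1-c1nc(SCc2ccc(Cl)cc2)n[nH]1`: 40900 nM

The value of compound 1 in this assay is a limit of the assay and not a number (the limit of > 50000 nM in this assay, at which 1 of the 3 values shown sits). Compound 3 carries the highest of the two numbers obtained; its nearest neighbour is compound 2, and the step of a 1.1-fold higher number from compound 2 to compound 3 (0.06 log units; within the scatter) sits within the scatter. The step of an at least 1.3-fold lower number from compound 1 to compound 2 (0.14 log units; that floor lies within the scatter) is only a floor, and that floor also lies within the scatter.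

Compound 4, `CC(C)Sc1n[nH]c(-n2[se]c3ccccc3c2=O)n1`, differs from compound 3 by isopropyl in place of 4-chlorobenzyl on a sulfur. For the measured compounds named here, the steps that bear on this change are those that alter the group on the sulfur: the exchange of phenyl for pentyl on the chain carbon between compound 1 and compound 2, and the exchange of pentyl for 4-chlorophenyl between compound 2 and compound 3. Neither moved the read-out beyond the scatter, and none separates the three compounds in this assay. A small branched alkyl group in place of the 4-chlorobenzyl is therefore expected to give a step of about a 1.0-fold lower number from compound 3 to compound 4 (0.01 log units; within the scatter), that is none beyond the scatter. For compound 4 the expected value in this assay is 40000 nM, with a range from 20000 nM to 60000 nM, and a fair chance that only a limit is returned.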

Compound 4, half-maximal inhibitory concentration: 34600 nM
For compound 4 the middle estimate is 1.2-fold (0.06 log units) above the measured one; measured number inside the range.
By their numbers in this assay, from the lowest: compounds 4, 2 and 3 (each within the scatter of the next). At a limit, above all of these: compound 1.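

In this assay, the group on the sulfur now extends to a small branched alkyl: isopropyl, with 3 heavy atoms and no ring, in place of 4-chlorobenzyl, with 8 heavy atoms and a six-membered aromatic ring, gives a 1.2-fold lower number from compound 3 to compound 4 (0.07 log units; within the scatter). Isopropyl in place of hexyl gives a 1.0-fold lower number from compound 2 to compound 4 (0.02 log units; within the scatter), so among compound 2, compound 3 and compound 4, neither the loss of the aromatic ring nor the change from a straight chain to a branched group separates the values. Compound 1 stands at a limit and not at a number, and isopropyl in place of benzyl can be read only as a floor, an at least 1.4-fold lower number from compound 1 to compound 4 (0.15 log units; that floor lies within the scatter): the limit of > 50000 nM in this assay, at which 1 of the 4 values shown sits.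

On these data alone, whether an amine or a carboxylic acid at the end of the chain on the sulfur would move the read-out beyond the scatter remains open, as does the effect of a change on the shared core rather than on the sulfur group. With only this one read-out shown, the flat response across these groups cannot be tied to any property of them.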